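From Nitro to Bromoethenyl on the Shared Core

A few compounds are considered here, and "the series" means these few. Any claim that something is new, unique, unknown or untested is made for them only; others in the source may bear on it.

Compound 2 `O=c1[nH]c(=O)n(COCCO)cc1[N+](=O)[O-]` carries a nitro on an aromatic carbon of the shared core, and in a functional assay (Oryctolagus cuniculus) for inhibition (a lower number here means a stronger inhibitor, a higher number a weaker inhibitor), compound 2 gives only a limit, > 400 ug/mL. Its companion compound 1 `Cc1cn(COCCO)c(=O)[nH]c1=O` differs from it in one place. In this assay compound 1 likewise gives only a limit, > 400 ug/mL. The step that the two limits leave unreadable from compound 1 to compound 2 therefore cannot be read, because both values sit at the limit of > 400 ug/mL in this assay, at which 2 of the 2 values shown sit. Compound 3 `O=c1[nH]c(=O)n(COCCO)cc1/C=C/Br` is not yet measured. Its difference from compound 2 is 2-bromoethenyl in place of nitro on an aromatic carbon: the nitro leaves and a 2-bromoethenyl enters on the same aromatic carbon, the entering group counting no hydrogen-bond acceptors where the nitro counted two. Among the compounds with values here, the one measured step touches this very position but is unreadable, so it offers no size and no direction for compound 3 in this assay, and nothing beyond the scatter can be foreseen from it. Compound 3 is therefore estimated at 400 ug/mL, expected to fall between 150 ug/mL and 1000 ug/mL. That estimate means an expected step of a number no higher from compound 2 to compound 3 (the limit leaves the size open), and the assay is expected most likely to report again only a limit.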

Compound 3, concentration for 50% inhibition: > 400 ug/mL
Compound 3: only a limit was reported; the forecaster's own chance of this, stated with the estimate: 70%; the middle value lies on the limit itself.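

In this assay no new step can be read: the steps joining compound 3 to compound 2 and to compound 1 stay unreadable, because all three compounds rest on the same limit: the limit of > 400 ug/mL in this assay, at which 3 of the 3 values shown sit.

The compounds shown leave open how strongly each inhibits, and whether methyl, nitro or 2-bromoethenyl on that aromatic carbon makes any difference.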